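Adding a Methyl Group to the Ring of Compound 3

This account rests on a few compounds, and the source may have more. Where it says the series, first, only, none or still open, it means among the compounds named here.

Compound 3 `C(=C/[C@@H]1CCCCN1)\c1ccccc1` gives the highest number of the three measured compounds in a functional assay on MCF7 cells (Homo sapiens) for inhibition, read by MTT assay, with a stated time of 24 h (a higher number here means a weaker inhibitor, a lower number a stronger inhibitor), at 9.15 ug/mL. Compound 1 `CCc1ccc(/C=C/[C@@H]2CCCCN2)cc1` gives 4.13 ug/mL in this assay, and compound 2 `O=[N+]([O-])c1ccc(/C=C/[C@@H]2CCCCN2)cc1` gives 2.15 ug/mL. The step of a 2.2-fold higher number from compound 1 to compound 3 (0.35 log units; beyond the scatter) and the step of a 4.3-fold higher number from compound 2 to compound 3 (0.63 log units; beyond the scatter) both show a higher number where hydrogen stands in place of a larger group on that aromatic carbon. Compound 4 `Cc1ccc(/C=C/[C@@H]2CCCCN2)cc1` differs from compound 3 by methyl in place of hydrogen on an aromatic carbon. Because of the step of a 2.2-fold higher number from compound 1 to compound 3 (0.35 log units; beyond the scatter), which runs the opposite way for a related group, a modest lowering is expected here. The expected step for compound 4 is a 1.5-fold lower number from compound 3 to compound 4 (0.18 log units; within the scatter). Compound 4 is therefore estimated to give about 6 ug/mL in this assay, within a range from 3 ug/mL to 12 ug/mL.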

Compound 4, half-maximal inhibitory concentration: 5.35 ug/mL
Compound 4: the middle estimate sits 1.1-fold (0.05 log units) above what was measured; the measured number falls inside the stated range.
By their numbers in this assay, from the lowest: compounds 2, 1, 4 and 3 (each within the scatter of the next, the first and the last beyond it).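

In this assay, methyl on this aromatic carbon, para to a group of 8 heavy atoms, cannot be told apart from hydrogen (a 1.7-fold lower number from compound 3 to compound 4 (0.23 log units; within the scatter)), although ethyl at the same place can. Methyl also cannot be told apart from ethyl (a 1.3-fold higher number from compound 1 to compound 4 (0.11 log units; within the scatter)), so the two alkyl groups read alike here. Nitro stays clearly apart from methyl (a 2.5-fold higher number from compound 2 to compound 4 (0.40 log units; beyond the scatter)), which the earlier compounds showed only against hydrogen and, within the scatter, against ethyl.

As far as these compounds go, whether an amine, a carboxylic acid or a longer chain at this place would fall with nitro or with the alkyl groups stays open. Nothing at hand bears on what lies behind these numbers.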